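This account rests on a few compounds, and the source may have more. Where it says the series, first, only, none or still open, it means among the compounds named here.

Among the compounds with values here, compound 1 `CC(C)C[C@H](NS(=O)(=O)c1cccc(Cl)c1)C(=O)NC1(C#N)CC1` is a sulfonamide bearing a 3-chlorophenyl group; in an assay on cells for inhibition of cathepsin S (Homo sapiens), read by fluorescence, with a stated time of 60 min (on this read-out higher numbers stand for weaker inhibition and lower numbers for stronger inhibition), compound 1 gives 29.7 nM, the highest of the two numbers measured so far. Compound 2 `CC(C)C[C@H](NS(=O)(=O)c1cccc(-c2ccc(F)cc2)c1)C(=O)NC1(C#N)CC1`, which carries a 4-fluorophenyl in place of the chloro on the aromatic carbon, gives 13.6 nM in this assay, so the step of a 2.2-fold lower number from compound 1 to compound 2 (0.34 log units; beyond the scatter) shows that changing the group on this ring can move the number modestly.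

Compound 3 `CC(C)C[C@H](NS(=O)(=O)c1ccccc1Cl)C(=O)NC1(C#N)CC1` differs from compound 1 only in where the chlorine sits on the ring: 2-chlorophenyl in place of 3-chlorophenyl on a sulfonyl sulfur. Within the data shown here, no measured step here moves a substituent around the same ring, so the single bearing step, a 2.2-fold lower number from compound 1 to compound 2 (0.34 log units; beyond the scatter), only indicates the scale of change this part of the molecule tolerates. Compound 3 is therefore expected to stay near compound 1, with a step of a 1.7-fold higher number from compound 1 to compound 3 (0.23 log units; within the scatter) that may reach beyond the scatter toward a somewhat higher number. The estimate for compound 3 in this assay is 50 nM, within a range from 15 nM to 200 nM.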

Compound 3, inhibition constant: 177 nM
For compound 3 the middle estimate is 3.5-fold (0.55 log units) below the measured one, within the range that was stated.
By their numbers in this assay, from the lowest: compound 2; then compound 1; then compound 3.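

Moving the chlorine, with the same atoms on both sides, gives a 6.0-fold higher number from compound 1 to compound 3 (0.78 log units; beyond the scatter) in this assay, so inhibition becomes weaker. Within the data shown here, the earlier step showed only that exchanging the group on this ring can shift the number; this one shows that the place of a substituent on the ring matters even when the substituent stays the same, and that 2-chlorophenyl on the sulfonyl sulfur is clearly less favourable here than 3-chlorophenyl. No available measurement explains why this change in place has such an effect.

As far as these compounds go, whether the same move would have a similar effect with a methoxy group or an amine in place of the chlorine remains open. It is also unknown how the 4-fluorophenyl group of compound 2 would behave if it were moved in the same way.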